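The compounds below may be only part of what the source reports. "The series", "measured", "known", "first", "only" and "open" are said of these compounds alone.

Measured compounds:
compound 1, `CC(C)(C)Cc1c(-c2ccc(Cl)cc2)sc(N)c1C(=O)c1ccc(Cl)cc1`, 1% in an assay on CHO cells for displacement of a labelled ligand from adenosine receptor A1 (Homo sapiens), read by scintillation counting, tested at 10 uM; a lower number here means less inhibition, a higher number more inhibition at the concentration tested (going by the name of the read-out)
compound 2, `Cc1ccc(C(=O)c2c(N)sc(Br)c2CC(C)(C)C)cc1`, 1%
compound 3, `Cc1ccc(C(=O)c2c(N)sc(-c3ccccc3)c2CC(C)(C)C)cc1`, 1%

All three share one core and differ only at its edges. In this assay compound 1 gives 1%, and the values of compound 2 and compound 3 lie within the scatter of it, so none of the three shows measurable displacement of the labelled ligand. Among the measured compounds shown here, the only single-point step among them, no change at the digits printed from compound 2 to compound 3 (within the scatter), swaps phenyl for bromo on an aromatic carbon and leaves the read-out where it was.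

Compound 4, `COc1ccc(-c2sc(N)c(C(=O)c3ccc(Cl)cc3)c2CC(C)(C)C)cc1`, is compound 1 with methoxy in place of chloro on an aromatic carbon, the change sitting on the six-membered carbon-only ring that carries the chloro in compound 1. For the measured compounds named here, no measured step touches this position, so the best guide is the general picture: every variation tried so far left the read-out flat. The expected step of a number 2 percentage points higher from compound 1 to compound 4 (within the scatter) is therefore none beyond the scatter. Compound 4 is estimated to give 3% in this assay, within 0% to 15%.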

Compound 4, a percentage reported as inhibition, at one concentration (the size of the read-out at that concentration, not a potency): 1%
For compound 4 the middle estimate is 2 percentage points above the measured one; the measured number falls inside the stated range.
By their numbers in this assay, from the lowest: compounds 1, 2, 3 and 4 (each within the scatter of the next).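

Going from 4-chlorophenyl to 4-methoxyphenyl brings no change at the digits printed from compound 1 to compound 4 (within the scatter) in this assay. Among the compounds shown here, this is the first reading for a change on this ring, and it shows that replacing chloro with methoxy, para to a large group, leaves the read-out where it was, even though the change adds a hydrogen-bond acceptor and one more heavy atom. Nothing at hand gives a reason for this flat result.

The compounds shown leave open whether a quite different group in this place, such as an amine or a carboxylic acid, would move the read-out in this assay. They also leave open whether any change to the shared core can produce clear displacement of the labelled ligand, as all four compounds lie within the scatter of one another.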